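Chloro to trifluoromethoxy at the aryl ether position

A few compounds are considered here, and "the series" means these few. Any claim that something is new, unique, unknown or untested is made for them only; others in the source may bear on it.

Measured so far:
Compound 1 `COC(=O)Nc1cc(-c2ccc(OC[C@@](C)(N)CC(C)C)c(C)c2)ccn1`: 0.08 nM
Compound 2 `CC(=O)Nc1cc(-c2ccc(OC[C@@](C)(N)CC(C)C)c(F)c2)ccn1`: 0.24 nM
Compound 3 `CC(=O)Nc1cc(-c2ccc(OC[C@@H](N)CC(C)C)c(Cl)c2)ccn1`: 0.06 nM

All three values come from an assay on brain (strain C57BL6) for displacement of a labelled ligand from AP2-associated protein kinase 1 (Mus musculus), read by scintillation counting, with a stated time of 1 h; a higher number here means a weaker inhibitor, a lower number a stronger inhibitor. Compound 3 sits at the low end of the three numbers. Compound 1 lies close to it, near enough that the two are within the usual scatter of this assay and cannot be ordered. Compound 2 is further off and beyond the scatter, so compound 2 gives a clearly higher number than compound 3. Note that compound 1 and compound 2 also differ from compound 3 in the group on the amine-bearing carbon, so no single change is isolated among the measured compounds.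

The next compound is compound 4 `CC(=O)Nc1cc(-c2ccc(OC[C@@H](N)CC(C)C)c(OC(F)(F)F)c2)ccn1`. It keeps the core and the side chain of compound 3 and differs in one place: trifluoromethoxy in place of chloro on an aromatic carbon. Among the compounds with values here, no measured pair shows this change, so there is no step to lean on. The reference compounds cover methyl, fluoro and chloro at this position and all stay at very low numbers; on that basis a small shift is expected, likely toward a higher number but probably within the scatter, and compound 4 is estimated at 0.12 nM (range 0.04 nM to 0.4 nM), a step of a 2.0-fold higher number from compound 3 to compound 4 (0.30 log units; within the scatter) expected.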

Compound 4, inhibition constant: 0.04 nM
For compound 4 the middle estimate is 3.0-fold (0.48 log units) above the measured one, within the range that was stated.
By their numbers in this assay, from the lowest: compounds 4, 3 and 1 (each within the scatter of the next); then compound 2.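

In this assay, trifluoromethoxy in place of chloro on the aromatic carbon ortho to the (2-amino-4-methylpentyl)oxy group gives a 1.5-fold lower number from compound 3 to compound 4 (0.18 log units; within the scatter) and so leaves compound 3 and compound 4 unordered, even though the entering group counts five heavy atoms against the one of chloro. Within the data shown here, this is the first change isolated at this position, since the earlier compounds carried methyl, fluoro or chloro there but formed no pair differing in one place, and it shows that a hydrogen-bond acceptor and four more heavy atoms can be added here with no change that stands out from the scatter. No supporting measurement bears on this result, so it gives no explanation for the step.

Still open, from the compounds shown here alone, is how far this holds for other groups on the same carbon, such as an amine, a carboxylic acid or a longer alkoxy chain. Also open, going by these compounds, is the contribution of the extra methyl on the amine-bearing carbon of compound 1 and compound 2, as each of them differs from compound 3 in more than one place.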